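Allyl for Cyclobutyl on the Carbamate Nitrogen

This account rests on a few compounds, and the source may have more. Where it says the series, first, only, none or still open, it means among the compounds named here.

Measured so far:
Compound 1, `CCCNC(=O)OC[C@H]1OC(n2cnc3c(NC4CCOC4)ncnc32)[C@H](O)[C@@H]1O`, gives 235 nM in an assay on DDT1 cells (Cricetulus griseus) for binding affinity to adenosine receptor A1 (Homo sapiens), read by radioligand binding; a higher number here means a weaker inhibitor, a lower number a stronger inhibitor.
Compound 2, `CCC/N=C(\S)OC[C@H]1OC(n2cnc3c(NC4CCOC4)ncnc32)[C@H](O)[C@@H]1O`, gives 50 nM in this assay.
Compound 3, `O=C(NC1CCC1)OC[C@H]1OC(n2cnc3c(NC4CCOC4)ncnc32)[C@H](O)[C@@H]1O`, gives 306 nM in this assay.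

Compound 3 carries the highest number of the three, but its standing depends on which neighbour is meant. Against compound 1 the gap is a 1.3-fold higher number from compound 1 to compound 3 (0.11 log units; within the scatter), so the two count as alike. Against compound 2 the gap is a 6.1-fold higher number from compound 2 to compound 3 (0.79 log units; beyond the scatter), a real difference.

Compound 4, `C=CCNC(=O)OC[C@H]1OC(n2cnc3c(NC4CCOC4)ncnc32)[C@H](O)[C@@H]1O`, differs from compound 3 in one place: allyl in place of cyclobutyl on an amide-type nitrogen. Within the data shown here, only one measured step touches this position, the swap from propyl to cyclobutyl, which gave a 1.3-fold higher number from compound 1 to compound 3 (0.11 log units; within the scatter). Allyl, like propyl, is a short open chain, so the data offer no ground for a shift beyond the scatter in this assay in either direction. The expected step is a 1.2-fold lower number from compound 3 to compound 4 (0.09 log units; within the scatter). Compound 4 is therefore estimated at 250 nM, with a likely range from 120 nM to 550 nM.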

Compound 4, inhibition constant: 524 nM
Compound 4: the middle estimate sits 2.1-fold (0.32 log units) below what was measured, within the range that was stated.
By their numbers in this assay, from the lowest: compound 2; then compounds 1, 3 and 4 (each within the scatter of the next, the first and the last beyond it).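

In this assay allyl and cyclobutyl on the amide-type nitrogen read as alike, at a 1.7-fold higher number from compound 3 to compound 4 (0.23 log units; within the scatter), but the open chains do not: allyl, with its one double bond, differs from the propyl of compound 1 by a 2.2-fold higher number from compound 1 to compound 4 (0.35 log units; beyond the scatter). The widest gap so far is a 10-fold higher number from compound 2 to compound 4 (1.02 log units; beyond the scatter), where the sulfur-bearing group of compound 2 gives way to the allylcarbamoyl group, so that comparison spans both the sulfur and the chain. Nothing available accounts for these steps.

Still open, as far as these compounds go, is whether a longer chain such as butyl, or a propargyl group with its triple bond, would sit with allyl or with propyl. Also open, from the compounds shown here alone, is whether the sulfur-bearing group would keep the number of compound 2 with allyl or cyclobutyl on its nitrogen.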